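The compounds below may be only part of what the source reports. "The series", "measured", "known", "first", "only" and "open" are said of these compounds alone.

Of the compounds shown here, three sharing one core have been measured in a functional assay on MDA-MB-231 cells (Homo sapiens) for inhibition, read by sulforhodamine B assay, tested at 10 uM; a lower number here means less inhibition, a higher number more inhibition at the concentration tested (going by the name of the read-out). Compound 1 `CC(=O)N1N=C(c2ccc(-n3ccnc3)cc2)CC1c1ccc(N(C)C)cc1` gives 5%. Compound 2 `CN(C)c1ccc(C2CC(c3ccc(-n4ccnc4)cc3)=NN2C(=O)CCCl)cc1` gives 2.1%, and compound 3 `CN(C)c1ccc(C2CC(c3ccc(-n4ccnc4)cc3)=NN2C(=O)c2ccc(F)cc2)cc1` gives 9.4%. These three numbers lie within the scatter of one another, so none of them stands apart: the step of a number 4.4 percentage points higher from compound 1 to compound 3 (within the scatter) and the step of a number 7.3 percentage points higher from compound 2 to compound 3 (within the scatter) are both too small to count, as is the step of a number 2.9 percentage points lower from compound 1 to compound 2 (within the scatter). Compound 3 is the point of departure for compound 4 `Cc1ccc(S(=O)(=O)N2N=C(c3ccc(-n4ccnc4)cc3)CC2c2ccc(N(C)C)cc2)cc1`. The change is (4-methylphenyl)sulfonyl in place of (4-fluorophenyl)carbonyl on an amine nitrogen in a ring. Each measured step also exchanged the group on this same ring nitrogen, a methyl, a 2-chloroethyl and a 4-fluorophenyl taking turns on the carbonyl carbon, and none of those exchanges moved the read-out beyond the scatter. Among the measured compounds shown here, none of them, however, replaced the carbonyl itself by a sulfonyl, so that part of the change has no measured counterpart among the three. With nothing in the measured steps pointing either way, the step expected in this assay is a number 2.4 percentage points lower from compound 3 to compound 4 (within the scatter), a size that stays within the scatter. Compound 4 is therefore expected to give 7%, with a range from 0% to 20%.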

Compound 4, a percentage reported as inhibition, at one concentration (the size of the read-out at that concentration, not a potency): 50.8%
The estimate for compound 4 lay 43.8 percentage points below the measured number, and the stated range ends below it.
By their numbers in this assay, from the lowest: compounds 2, 1 and 3 (each within the scatter of the next); then compound 4.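

The ring nitrogen, where exchanges among carbonyl groups had made no difference, turns out to be a position where this assay can respond strongly: the new group gives a large step (a number 41.4 percentage points higher from compound 3 to compound 4 (beyond the scatter)), and the comparisons with the other two compounds are as large (a number 48.7 percentage points higher from compound 2 to compound 4 (beyond the scatter)) and (a number 45.8 percentage points higher from compound 1 to compound 4 (beyond the scatter)). Acetyl, (2-chloroethyl)carbonyl and (4-fluorophenyl)carbonyl all lie within the scatter of one another, whereas (4-methylphenyl)sulfonyl lies beyond the scatter of each, so among these four compounds the one sulfonyl stands apart from the three carbonyls. Nothing measured here accounts for the size of this step.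

The exchange altered two things at once, the carbonyl becoming a sulfonyl and the fluorine on the ring giving way to a methyl, so the compounds shown cannot say which of the two matters. A (4-methylphenyl)carbonyl group or a (4-fluorophenyl)sulfonyl group on the same nitrogen would separate them, and a methylsulfonyl group would ask whether the aromatic ring is needed at all.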